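The compounds below may be only part of what the source reports. "The series", "measured", "known", "first", "only" and "open" are said of these compounds alone.

Compound 1 `CS(=O)(=O)N[C@H]1[C@H]([C@@H](O)[C@H](O)CNC(=O)c2ccc(Cl)cc2)O[C@@](OCc2cccc(F)c2F)(C(=O)O)C[C@@H]1O` gives 17000 nM in an in vitro assay on cells for binding affinity to myelin-associated glycoprotein (Mus musculus), read by surface plasmon resonance; on this read-out lower numbers stand for tighter binding and higher numbers for weaker binding. Compound 2 `O=C(CC1CC1)N[C@H]1[C@H]([C@@H](O)[C@H](O)CNC(=O)c2ccc(Cl)cc2)O[C@@](OCc2cccc(F)c2F)(C(=O)O)C[C@@H]1O` gives 4100 nM in this assay.

Compound 2 holds the lower of the two numbers, set apart from compound 1 by a 4.1-fold lower number from compound 1 to compound 2 (0.62 log units; beyond the scatter). Compound 3 `O=C(CC1CCC1)N[C@H]1[C@H]([C@@H](O)[C@H](O)CNC(=O)c2ccc(Cl)cc2)O[C@@](OCc2cccc(F)c2F)(C(=O)O)C[C@@H]1O` differs from compound 2 by cyclobutyl in place of cyclopropyl on a saturated chain carbon bound to a carbonyl carbon. Among the measured compounds shown here, no measured step swaps one small saturated ring for another; the single measured step, a 4.1-fold lower number from compound 1 to compound 2 (0.62 log units; beyond the scatter), replaced a whole different group on the same nitrogen, so it offers only a loose guide. Compound 3 is therefore expected to give about 3500 nM (range 1500 nM to 9000 nM) in this assay, an expected step of a 1.2-fold lower number from compound 2 to compound 3 (0.07 log units; within the scatter) that should stay within the scatter.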

Compound 3, dissociation constant in the myelin-associated glycoprotein assay: 5800 nM
Compound 3: the middle estimate sits 1.7-fold (0.22 log units) below what was measured; the range from low to high includes it.
By their numbers in the myelin-associated glycoprotein assay, from the lowest: compounds 2 and 3 (each within the scatter of the next); then compound 1.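

In the myelin-associated glycoprotein assay, the ring swap gives a 1.4-fold higher number from compound 2 to compound 3 (0.15 log units; within the scatter), so this place tolerates cyclobutyl as well as cyclopropyl with no readable change in binding. The step of a 2.9-fold lower number from compound 1 to compound 3 (0.47 log units; beyond the scatter) shows that the advantage over methylsulfonyl survives the swap. In a physicochemical assay for lipophilicity, using the shake flask method, measured as octanol-water partition, at pH 7.4 (on this read-out higher numbers stand for higher lipophilicity and lower numbers for lower lipophilicity), compound 2 gives 0.31 and compound 3 gives 0.75. The same swap does register in the physicochemical assay, as higher lipophilicity without a matching change in binding: the measured distribution coefficient of compound 2, 0.31, and of compound 3, 0.75, a number 0.44 log units higher (beyond the scatter)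

On these data alone, whether a cyclopentyl ring, a longer open chain or an amine at this place would keep the binding remains open. Two small rings also cannot show whether binding and lipophilicity are linked here.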